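From 4-chlorobenzyl to 2,3,4,5,6-pentafluorobenzyl on a shared core

The source may report more compounds than this note shows. Statements on the series, on what has been measured and on what is new or still open speak of the compounds shown alone.

Two measured compounds open this series, and both carry the same core. In a physicochemical assay for lipophilicity, using the shake flask method, measured as octanol-water partition, at pH 7.4 (on this read-out lower numbers stand for lower lipophilicity and higher numbers for higher lipophilicity), compound 1 `CO[C@]1(C(=O)O)C[C@H](O)[C@@H](NC(C)=O)[C@H]([C@@H](O)[C@H](O)CNC(=O)c2ccccc2)O1` has the entry "not determined" (no result reported) and so offers nothing to compare against. In this assay, among the measured compounds shown here, compound 2 `CC(=O)N[C@H]1[C@H]([C@@H](O)[C@H](O)CNC(=O)c2ccc(Cl)cc2)O[C@@](OCc2ccc(Cl)cc2)(C(=O)O)C[C@@H]1O` gives 0.36 as the only number so far, which means it cannot yet be ranked against anything.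

Compound 3 `CC(=O)N[C@H]1[C@H]([C@@H](O)[C@H](O)CNC(=O)c2ccc(Cl)cc2)O[C@@](OCc2c(F)c(F)c(F)c(F)c2F)(C(=O)O)C[C@@H]1O` is still unmeasured. It differs from compound 2 in one place, on a saturated chain carbon bound to an oxygen on a saturated carbon, and 2,3,4,5,6-pentafluorophenyl in place of 4-chlorophenyl on a saturated chain carbon bound to an oxygen on a saturated carbon is the full count of that change. Cut one bond further out, it reads 4-chlorobenzyl to 2,3,4,5,6-pentafluorobenzyl.

For the measured compounds named here, no measured pair shows what such a swap does. Both groups are aromatic rings of carbon only, with no net charge and no hydrogen-bond donors or acceptors, so only a small move away from compound 2 at 0.36 is expected. Estimated is a slight fall a number 0.16 log units lower from compound 2 to compound 3 (within the scatter) that stays within the usual scatter of repeated measurements. For compound 3 the estimated value is 0.2 with a range from -0.2 to 0.6 on this scale.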

Compound 3, distribution coefficient: -0.11
Beside the measured number, compound 3's estimate is 0.31 log units above it; the measured number falls inside the stated range.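

In this assay, among the compounds shown here, putting 2,3,4,5,6-pentafluorophenyl in place of 4-chlorophenyl on a saturated chain carbon bound to an oxygen on a saturated carbon gives a number 0.47 log units lower from compound 2 to compound 3 (beyond the scatter) and so provides the first measured step at this position. It shows that this read-out can respond to a change at this place even when both groups are six-membered aromatic rings of carbon only, with no net charge and no hydrogen-bond donors or acceptors; what differs is the set of atoms on the ring, with one chlorine leaving and five fluorines entering, and the group growing from 7 to 11 heavy atoms. Nothing shown here explains the direction or the size of this step.

For the compounds shown here, a single step cannot separate the loss of the chlorine from the gain of the fluorines, so it remains unclear whether a 4-fluorobenzyl group, with only one fluorine on the ring, would read closer to compound 2 or to compound 3. As far as these compounds go, it is also open how a group without an aromatic ring, such as a hexyl chain, would behave at this position.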